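The source may hold more compounds than are shown below. What is called first, only, known or untested is meant among the compounds shown, and "the series" means these compounds.

The study follows a small set of diacylated isothiourea-type compounds in a functional assay on HepG2 cells (Homo sapiens) for cytotoxicity, read by MTT assay, with a stated time of 72 h; a lower number here means that less compound is tolerated, a higher number that more compound is tolerated. Compound 3 has the structure `CS/C(=N\C(=O)c1cccs1)NC(=O)c1cccs1`. In this assay compound 3 reaches only the limit of > 100000 nM, which is a limit of the assay and not a number. Compound 2, with the structure `O=C(/N=C(/NC(=O)c1cccs1)[Se]Cc1ccccc1)c1cccs1`, differs from compound 3 in one place: a group of 8 heavy atoms (7 carbon, 1 selenium; one six-membered aromatic ring of carbon only) in place of a group of 2 heavy atoms (1 carbon, 1 sulfur; no ring), on a carbon with a double bond to nitrogen. In this assay compound 2 gives 81500 nM. The step of an at least 1.2-fold lower number from compound 3 to compound 2 (0.08 log units; that floor lies within the scatter) is bounded on one side by the limit of > 100000 nM in this assay, at which 2 of the 3 values shown sit, so its true size is not fixed.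

Compound 1 has the structure `CS/C(=N\C(=O)c1ccco1)NC(=O)c1ccco1`. In this assay compound 1 also sits at the limit of > 100000 nM, a limit and not a number. The difference between the core of compound 1 and the core of compound 3 is not broken down here.

Compound 4, the structure `O=C(/N=C(/NC(=O)c1ccco1)[Se]Cc1ccccc1)c1ccco1`, is not yet measured. It differs from compound 1 by the same change that separates compound 2 from compound 3: a group of 8 heavy atoms (7 carbon, 1 selenium; one six-membered aromatic ring of carbon only) in place of a group of 2 heavy atoms (1 carbon, 1 sulfur; no ring), on a carbon with a double bond to nitrogen. Among the measured compounds shown here, for compound 4 the expected step of an at least 1.1-fold lower number from compound 1 to compound 4 (0.04 log units; that floor lies within the scatter) rests on the one earlier instance, where compound 3 went to compound 2 with an at least 1.2-fold lower number from compound 3 to compound 2 (0.08 log units; that floor lies within the scatter), and on the fact that compound 1 stands at the same limit as compound 3, so the estimate is put near the value of compound 2. The estimated value for compound 4 in this assay is therefore 90000 nM, expected to lie between 45000 nM and 180000 nM.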

Compound 4, concentration lethal to 50% of the cells: 76500 nM
The estimate for compound 4 lay 1.2-fold (0.07 log units) above the measured number; the measured number falls inside the stated range.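

In this assay, placing the group of 8 heavy atoms, with its selenium and its six-membered aromatic ring, in place of methylsulfanyl on the carbon with a double bond to nitrogen gives an at least 1.3-fold lower number from compound 1 to compound 4 (0.11 log units; that floor lies within the scatter). Set beside the earlier case on the other core, the two steps read: the same change on two cores in this assay, an at least 1.2-fold lower number (0.08 log units; that floor lies within the scatter) from compound 3 to compound 2 and an at least 1.3-fold lower number (0.11 log units; that floor lies within the scatter) from compound 1 to compound 4; the limit leaves it open whether they differ This shows only that on both cores the selenium compound gives a number while its methylsulfanyl partner stays at a limit, and it does not show that the change lowers the number by a real amount or by the same amount on each core, because each step has only a floor that lies within the scatter and its true size stays unfixed: the limit of > 100000 nM in this assay, at which 2 of the 4 values shown sit.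

The compounds shown also leave open which part of the entering group matters, since selenium and the aromatic ring always arrive together and no group with sulfur in place of selenium stands among them. On these data alone, how an amine, a carboxylic acid or a longer chain on that same carbon would read in this assay also remains open.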